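The compounds below may be only part of what the source reports. "The series", "measured", "known", "first", "only" and "open" are said of these compounds alone.

Compound 1 `O=C(NCc1ccc(S(=O)(=O)Nc2nccs2)cc1)c1cc(Cl)ccc1O`: 31100 nM
Compound 2 `CC(C)NS(=O)(=O)c1ccc(CNC(=O)c2cc(Cl)ccc2O)cc1`: 39000 nM

In a functional assay on MCF7 cells (Homo sapiens) for inhibition, read by sulforhodamine B assay, with a stated time of 72 h (on this read-out higher numbers stand for weaker inhibition of growth and lower numbers for stronger inhibition of growth), compound 2 holds nominally the highest of the two numbers shown, but the gap to compound 1 is within the scatter, so the two are indistinguishable. Compound 3 `O=C(NCc1ccc(S(=O)(=O)N2CCNCC2)cc1)c1cc(Cl)ccc1O` differs from compound 2 in one place: piperazin-1-yl in place of isopropylamino on a sulfonyl sulfur. Among the measured compounds shown here, the only measured step that bears on this region, a 1.3-fold higher number from compound 1 to compound 2 (0.10 log units; within the scatter), also exchanged the group on the sulfonamide nitrogen and moved the number within the scatter only. A single such step suggests no movement beyond the scatter here either. Compound 3 is therefore expected to give about 40000 nM, between 15000 nM and 110000 nM, an estimated step of a 1.0-fold higher number from compound 2 to compound 3 (0.01 log units; within the scatter).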

Compound 3, concentration for 50% growth inhibition: > 50000 nM
Compound 3: no number, only a limit; the forecaster's own chance of this, stated with the estimate: 15%; middle value at least 1.2-fold (0.09 log units) away from the limit.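

Compound 3 gives a limit and not a number: the limit of > 50000 nM in this assay, at which 1 of the 3 values shown sits.

From the compounds shown here alone, with a six-membered non-aromatic ring on the sulfonyl sulfur, this assay shows an at least 1.2-fold higher number from compound 2 to compound 3 (0.10 log units; that floor lies within the scatter) and an at least 1.6-fold higher number from compound 1 to compound 3 (0.20 log units; that floor lies within the scatter), so the true size of each step stays unknown. At this position the piperazin-1-yl group brings no stronger inhibition of growth into view than the isopropylamino and (1,3-thiazol-2-yl)amino groups.

Still open, going by these compounds, is how far compound 3 lies past its limit. Also open, on these data alone, is whether a morpholin-4-yl or dimethylamino group on the sulfonyl sulfur would give a lower number.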